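A few compounds are considered here, and "the series" means these few. Any claim that something is new, unique, unknown or untested is made for them only; others in the source may bear on it.

Measured compounds:
compound 1 `CC1=C(C(=O)OC(C)C)C(c2cccc([N+](=O)[O-])c2)NC(=O)N1` gives 46600 nM in an assay on HEK293 cells for antagonist activity at Voltage-dependent L-type calcium channel subunit alpha-1D (Rattus norvegicus), read by FLIPR; on this read-out higher numbers stand for weaker inhibition and lower numbers for stronger inhibition
compound 2 `CC1=C(C(=O)OC(C)C)C(c2cccc([N+](=O)[O-])c2)N(C(=O)C(C)C)C(=O)N1` gives 990 nM
compound 3 `COC(=O)C1=C(C)NC(=S)N(C(=O)OC(C)C)C1c1cccc([N+](=O)[O-])c1` gives 880 nM

Compound 2 stands second highest of the three numbers. Its nearest neighbour is compound 3, whose value lies within the scatter of that of compound 2, so the two cannot be ordered. Compound 1 stands far above: the step of a 47-fold lower number from compound 1 to compound 2 (1.67 log units; beyond the scatter) is large and shows that placing an isopropylcarbonyl on the ring nitrogen in place of hydrogen goes with a much lower number.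

Compound 4 `CC1=C(C(=O)OC(C)C)C(c2cccc([N+](=O)[O-])c2)N(C(=O)OC(C)C)C(=O)N1` is the next step from compound 2. The change is isopropoxy in place of isopropyl on a carbonyl carbon; seen one bond further out, it reads isopropylcarbonyl to isopropoxycarbonyl on the ring nitrogen. Among the compounds with values here, no measured step bears directly on it. Within the data shown here, the step from compound 1 to compound 2 shows only that a carbonyl group on that nitrogen matters, not how its far end matters. Compound 3, which differs in other places as well, carries an isopropoxycarbonyl on its ring nitrogen and gives a number close to that of compound 2. From this, compound 4 is expected to differ from compound 2 by a 1.2-fold lower number from compound 2 to compound 4 (0.07 log units; within the scatter), no step beyond the scatter. Compound 4 is estimated at 850 nM, in the range from 300 nM to 2500 nM.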

Compound 4, half-maximal inhibitory concentration: 660 nM
Compound 4: middle estimate off by 1.3-fold (0.11 log units), on the high side, and the stated range covers the measured number.
By their numbers in this assay, from the lowest: compounds 4, 3 and 2 (each within the scatter of the next); then compound 1.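

In this assay, exchanging isopropyl for isopropoxy on the carbonyl carbon gives a 1.5-fold lower number from compound 2 to compound 4 (0.18 log units; within the scatter). This step lies within the scatter, so compound 2 and compound 4 cannot be ordered, and the two far ends of the carbonyl group cannot be told apart at this position. The large drop seen earlier is also no longer tied to a single group, since isopropoxycarbonyl in place of hydrogen on the same amide-type nitrogen gives a 71-fold lower number from compound 1 to compound 4 (1.85 log units; beyond the scatter), so two different carbonyl groups on this nitrogen now go with a much lower number than the hydrogen does, and no other measurement is available to explain this.

The compounds shown leave open whether the carbonyl itself is needed, as a plain isopropyl attached directly to the ring nitrogen would test. They also leave open how far the far end of the carbonyl group can be changed, for example to a longer chain, a phenyl ring, an amine or a carboxylic acid, before the number in this assay moves beyond the scatter.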